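Replacing bromo with 4-(trifluoromethyl)phenyl on compound 2

The source may report more compounds than this note shows. Statements on the series, on what has been measured and on what is new or still open speak of the compounds shown alone.

Compound 1 `Cc1ccc(-c2ccccc2S(=O)(=O)N2CCC(N3CCC(C)CC3)CC2)cc1`: > 5000 nM (a limit)
Compound 2 `CC1CCN(C2CCN(S(=O)(=O)c3ccccc3Br)CC2)CC1`: > 5000 nM (a limit)

In an ADME assay on HCT-116 cells (Homo sapiens) for cytotoxicity, read by CellTiter-Glo, with a stated time of 72 h (on this read-out higher numbers stand for weaker inhibition and lower numbers for stronger inhibition), compound 2 gives > 5000 nM, which is a limit and not a number. Compound 3 `CC1CCN(C2CCN(S(=O)(=O)c3ccccc3-c3ccc(C(F)(F)F)cc3)CC2)CC1` differs from compound 2 by one change: 4-(trifluoromethyl)phenyl in place of bromo on an aromatic carbon. For the measured compounds named here, the only measured step that bears on it is a step that the two limits leave unreadable from compound 1 to compound 2, so it offers no size to carry over. Both measured compounds sit together: the limit of > 5000 nM in this assay, at which 2 of the 2 values shown sit. Compound 1, with 4-methylphenyl in that place, gives > 5000 nM, again a limit. No clear step in either direction is therefore expected in this assay. The expected step is a step that the limit leaves unreadable from compound 2 to compound 3. For compound 3 the estimate is 7000 nM, with an expected range of 3000 nM to 20000 nM.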

Compound 3, half-maximal inhibitory concentration: > 5000 nM
Compound 3: only a limit was reported; the forecaster's own chance of this, stated with the estimate: 85%; the middle value lies beyond the limit too.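

In this assay, for the compounds shown here, compound 1, compound 2 and compound 3 each give only a limit and not a number, so no step among them can be read. The compounds shown leave open where their true values lie and whether swapping these groups changes anything.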